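Swapping One Aromatic Group in a Cell Growth Test

A few compounds are considered here, and "the series" means these few. Any claim that something is new, unique, unknown or untested is made for them only; others in the source may bear on it.

In a functional assay on U-937 cells (Homo sapiens) for antiproliferative activity, read by MTT assay, with a stated time of 72 h (on this read-out higher numbers stand for weaker inhibition and lower numbers for stronger inhibition), compound 2 (`Cc1ccc(-c2noc(CCCCCCC(=O)Nc3ccccc3N)n2)cc1`) gives 460 nM as its result. Compound 1 (`O=C(CCCCCCc1nc(-c2ccccc2Cl)no1)NO`) gives 750 nM as its result, and these two values lie within the scatter of each other. Compound 3 (`Nc1ccccc1NC(=O)CCCCCCc1nc(-c2ccccc2Cl)no1`) differs from compound 2 in one place (2-chlorophenyl in place of 4-methylphenyl on an aromatic carbon) with 2-chlorophenyl in place of 4-methylphenyl on an aromatic carbon. Within the data shown here, no measured pair shows this change on its own. Compound 3 shares 2-chlorophenyl with compound 1, which differs elsewhere, so compound 1 at 750 nM offers only a loose guide. In this assay no step beyond the scatter is expected, and the estimate is a small shift toward weaker inhibition, a 1.3-fold higher number from compound 2 to compound 3 (0.12 log units; within the scatter) in size. Compound 3 is estimated at 600 nM with an expected range from 250 nM to 1400 nM in this measurement.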

Compound 3, half-maximal inhibitory concentration: 6910 nM
The estimate for compound 3 lay 12-fold (1.06 log units) below the measured number, and the stated range ends below it.
By their numbers in this assay, from the lowest: compounds 2 and 1 (each within the scatter of the next); then compound 3.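

In this assay, the aromatic group on the carbon between two ring nitrogen atoms proves far from interchangeable: 2-chlorophenyl in place of 4-methylphenyl gives a 15-fold higher number from compound 2 to compound 3 (1.18 log units; beyond the scatter), even though both groups have the same count of heavy atoms and a single carbon ring. The other end of the molecule matters as well, since with 2-chlorophenyl held fixed, 2-aminophenyl in place of hydroxy on the amide-type nitrogen gives a 9.2-fold higher number from compound 1 to compound 3 (0.96 log units; beyond the scatter). No measurement shown here explains either step.

On these data alone, whether the first step comes from adding the chlorine, from where it sits or from losing the methyl stays open, and plain phenyl, 4-chlorophenyl or 2-methylphenyl at this position would help separate these. Also open, as far as these compounds go, is how 4-methylphenyl behaves with hydroxy on the amide-type nitrogen.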